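Swapping a Dialkylamino Group for a Secondary Amine

The source may hold more compounds than are shown below. What is called first, only, known or untested is meant among the compounds shown, and "the series" means these compounds.

Measured compounds:
compound 1, `CCCCN(CC)c1nc(C)nc2c1n(C)c(=O)n2-c1ccc(C(C)C)cc1Br`, 5 nM
compound 2, `CCCN(CCC)c1nc(C)nc2c1n(C)c(=O)n2-c1ccc(C(C)C)cc1Br`, 7.6 nM
compound 3, `CCCN(CC1CC1)c1nc(C)nc2c1n(C)c(=O)n2-c1ccc(C(C)C)cc1Br`, 5.7 nM

In an assay on HEK293 cells for binding affinity to corticotropin-releasing factor receptor 1 (Homo sapiens), read by radioligand binding (a lower number here means a stronger inhibitor, a higher number a weaker inhibitor), compound 3 stands second highest of the three numbers, with both neighbours close by: a 1.1-fold higher number from compound 1 to compound 3 (0.06 log units; within the scatter), and a 1.3-fold lower number from compound 2 to compound 3 (0.12 log units; within the scatter).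

Compound 4, `CCCCC(CC)Nc1nc(C)nc2c1n(C)c(=O)n2-c1ccc(C(C)C)cc1Br`, differs from compound 3 by (1-ethylpentyl)amino in place of (cyclopropylmethyl)(propyl)amino on an aromatic carbon. The entering group has no ring and carries 1 hydrogen-bond donor, whereas the leaving group had 0 hydrogen-bond donors. The measured steps all reshuffle carbon chains on a nitrogen that bears no hydrogen: a 1.5-fold higher number from compound 1 to compound 2 (0.18 log units; within the scatter), a 1.1-fold higher number from compound 1 to compound 3 (0.06 log units; within the scatter), a 1.3-fold lower number from compound 2 to compound 3 (0.12 log units; within the scatter); each stayed within the scatter. None of them tests a nitrogen gaining a hydrogen, so that part of the change is uncharted. The step is therefore expected to be small but less certain than the ones already seen: a 1.6-fold higher number from compound 3 to compound 4 (0.20 log units; within the scatter). The estimate for compound 4 is 9 nM, between 2.5 nM and 40 nM.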

Compound 4, inhibition constant: 15.1 nM
For compound 4 the middle estimate is 1.7-fold (0.22 log units) below the measured one, within the range that was stated.
By their numbers in this assay, from the lowest: compounds 1, 3, 2 and 4 (each within the scatter of the next, the first and the last beyond it).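

For the compounds shown here, putting a hydrogen on this nitrogen, as (1-ethylpentyl)amino does, gives the first steps at this position that go beyond the scatter, though only modestly: a 2.6-fold higher number from compound 3 to compound 4 (0.42 log units; beyond the scatter) and a 3.0-fold higher number from compound 1 to compound 4 (0.48 log units; beyond the scatter). Against dipropylamino the change stays within the scatter, at a 2.0-fold higher number from compound 2 to compound 4 (0.30 log units; within the scatter), so the size of the loss depends on the comparison compound. No available evidence explains this shift. Going by these compounds, the change alters both the hydrogen and the chain arrangement, so their separate contributions remain open. A shorter branched group such as (1-ethylpropyl)amino could show whether the same rise appears with less carbon.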